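The source may report more compounds than this note shows. Statements on the series, on what has been measured and on what is new or still open speak of the compounds shown alone.

Compound 1, `OC[C@H]1O[C@@H](n2cnc3c(NCc4ccc(F)c(F)c4F)ncnc32)[C@H](O)[C@@H]1O`, in a functional assay on K562 cells (Homo sapiens) for antiproliferative activity, with a stated time of 72 h (on this read-out lower numbers stand for stronger inhibition and higher numbers for weaker inhibition), gives > 166000 nM, which is a limit of the assay and not a number.
Compound 2, `OC[C@H]1O[C@@H](n2cnc3c(NCc4ccc(F)c(Cl)c4)ncnc32)[C@H](O)[C@@H]1O`, gives 5500 nM.
Compound 3, `OC[C@H]1O[C@@H](n2cnc3c(NCc4cc(O)cc(O)c4)ncnc32)[C@H](O)[C@@H]1O`, gives > 166000 nM, again a limit rather than a number.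

Compound 3 therefore stands at the weak end of what has been shown: its value is only a limit, and (the limit of > 166000 nM in this assay, at which 2 of the 3 values shown sit), so compound 3 and compound 1 cannot be told apart from each other in this assay. For the measured compounds named here, the one step that reads clearly into compound 3 is an at least 30-fold higher number from compound 2 to compound 3 (1.47 log units; beyond the scatter). The other readable step, an at least 30-fold lower number from compound 1 to compound 2 (1.47 log units; beyond the scatter), runs between the two halogenated groups and shows how much a small change on that part of the molecule can matter. Compound 4, `OC[C@H]1O[C@@H](n2cnc3c(NCc4ccc(C(F)(F)F)cc4)ncnc32)[C@H](O)[C@@H]1O`, has not yet been measured. The change from compound 3 is this: 4-(trifluoromethyl)phenyl in place of 3,5-dihydroxyphenyl on a saturated chain carbon bound to a nitrogen on an aromatic ring. This brings compound 4 closer in kind to compound 1 and compound 2, which carry the 2,3,4-trifluorophenyl and 3-chloro-4-fluorophenyl groups, than to compound 3 with its hydroxy groups. Those two earlier compounds sit far apart from each other, one at the limit and one with a number, so the expectation for compound 4 is uncertain. Compound 4 is expected to give a number rather than a limit, estimated at 25000 nM with a range from 4000 nM to 166000 nM. That estimate means an at least 6.6-fold lower number from compound 3 to compound 4 (0.82 log units; beyond the scatter), with a real chance that only a limit is reported again.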

Compound 4, half-maximal inhibitory concentration: > 166000 nM
Compound 4: only a limit was reported; the forecaster's own chance of this, stated with the estimate: 35%; at least 6.6-fold (0.82 log units) between middle value and limit.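

On the saturated chain carbon bound to a nitrogen on an aromatic ring, the 4-(trifluoromethyl)phenyl group of compound 4 carries no hydrogen-bond donors, unlike the 3,5-dihydroxyphenyl group of compound 3, yet compound 4 still gives only a limit of the assay and not a number. Carrying fluorine on this ring is also not enough to match compound 2 with its 3-chloro-4-fluorophenyl group, as shown by an at least 30-fold higher number from compound 2 to compound 4 (1.47 log units; beyond the scatter). Compound 2 is now the only compound with a number, and the steps from compound 3 to compound 4 and from compound 1 to compound 4 cannot be read because both ends of each step are limits: the limit of > 166000 nM in this assay, at which 3 of the 4 values shown sit.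

On these data alone, how compound 1, compound 3 and compound 4 rank among themselves stays open, as does which part of the 3-chloro-4-fluorophenyl group of compound 2 matters. A 3-chlorophenyl or a 4-fluorophenyl group at the same place would separate the contributions of the chlorine and the fluorine, and a longer chain to the ring would test the length of the link.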